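Flipping One Double Bond and Its Expected Effect on Cytotoxicity

This account rests on a few compounds, and the source may have more. Where it says the series, first, only, none or still open, it means among the compounds named here.

In a functional assay on HeLa cells (Homo sapiens) for cytotoxicity, read by MTT assay, with a stated time of 72 h (on this read-out lower numbers stand for stronger inhibition and higher numbers for weaker inhibition), compound 1 `CCCCC(C)C/C(=C/[C@@]1(CC)OC(=O)C[C@@H]1O)CC` gives 31200 nM as its measured value. Alongside it, compound 2 `CC/C=C/[C@H]1C[C@](O)(CC)[C@@H]([C@]2(CC)OC(=O)C[C@@H]2O)[C@@H]1C` gives 29000 nM as its value, and these two numbers lie within the usual scatter of each other. For the measured compounds named here, compound 1 therefore stands level with the only other measured compound.

The next compound, compound 3 `CCCCC(C)C/C(=C\[C@@]1(CC)OC(=O)C[C@@H]1O)CC`, is a very close relative of compound 1, and the two compounds have the same atoms and bonds; at least one stereo element is drawn with a configuration in one of them and without one in the other: 1 of 4 stereo elements differ; a double bond is drawn E in compound 1 and Z in compound 3 is the whole change. A double bond is drawn E in compound 1 and Z in compound 3, which means that the groups on that bond take the other fixed arrangement while the atoms and bonds stay the same. Going by the values given here, no measured pair shows what such a change does, so the only guide is compound 1 at 31200 nM and the expectation has to stay wide. The step of a 1.0-fold lower number from compound 1 to compound 3 (0.02 log units; within the scatter) is expected to stay within the scatter, with no clear direction. Compound 3 is expected at 30000 nM within an estimated range of 13000 nM to 65000 nM on this measure.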

Compound 3, half-maximal inhibitory concentration: 4700 nM
Estimate against measurement, compound 3: 6.4-fold (0.81 log units) above, outside the stated range (below it).
By their numbers in this assay, from the lowest: compound 3; then compounds 2 and 1 (each within the scatter of the next).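

The double bond turns out to be a place where arrangement alone counts: in this assay the switch from E to Z, with no atom or bond changed, gives a 6.6-fold lower number from compound 1 to compound 3 (0.82 log units; beyond the scatter). For the compounds shown here, the earlier compounds could not show this, as the only two measured values stood level and no single change had yet been seen to move the number, whereas this step is modest but lies beyond the scatter. One caution applies to reading it as a clean comparison of two fixed arrangements: the fact that one of compounds 1 and 3 is drawn with a defined configuration and the other without, at the place where they differ

On these data alone, whether the Z arrangement would keep its lower number on other members remains open, for example if the side chain of compound 3 gave way to a longer chain or came to carry an amine. The pair also says nothing about how compound 3 acts on the cells, and with so few compounds the size of this step cannot yet be taken as typical of such a change elsewhere.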